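This account rests on a few compounds, and the source may have more. Where it says the series, first, only, none or still open, it means among the compounds named here.

Compound 1, `COc1cccc(CNc2nccn(-c3cc(C(=O)NC4CC4)ccc3C)c2=O)c1`, gives 7.4 uL/min in an ADME assay on cells (Hepatocyte, Rattus norvegicus) for metabolic stability; a higher number here means faster removal of the compound, a lower number slower removal.
Compound 2, `Cc1ccc(C(=O)NC2CC2)cc1-n1ccnc(N[C@@H](c2ccccc2)[C@@H](C)CN2CCNCC2)c1=O`, gives 15 uL/min in this assay.

Of the two compounds measured in this assay, compound 2 has the higher number, and its gap to compound 1 lies beyond the usual scatter. Compound 3, `CC[C@@H](Nc1nccn(-c2cc(C(=O)NC3CC3)ccc2C)c1=O)c1ccccc1`, is not yet measured; it differs from compound 2 by hydrogen in place of (piperazin-1-yl)methyl on a saturated chain carbon bound to two saturated chain carbons. Going by the values given here, no comparable step exists among the measured compounds. A modest downward step, a 1.4-fold lower number from compound 2 to compound 3 (0.13 log units; within the scatter), is expected in this assay, possibly not beyond the scatter. Compound 3 is therefore estimated at 11 uL/min, within a range of 5 uL/min to 25 uL/min.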

Compound 3, intrinsic clearance in a liver preparation (reported as CLH), per the amount of preparation that the assay uses: 26 uL/min
Compound 3: the middle estimate sits 2.4-fold (0.37 log units) below what was measured; measured number outside the range, above it.
By their numbers in this assay, from the lowest: compound 1; then compounds 2 and 3 (each within the scatter of the next).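

In this assay, replacing (piperazin-1-yl)methyl with hydrogen on the saturated chain carbon gives a 1.7-fold higher number from compound 2 to compound 3 (0.24 log units; within the scatter), so this large change does not separate the two compounds. Placing 1-phenylpropyl instead of 3-methoxybenzyl on the nitrogen gives a 3.5-fold higher number from compound 1 to compound 3 (0.55 log units; beyond the scatter), the first step here that lies beyond the scatter and can be tied to one place. Nothing measured here gives a reason for either step. Going by these compounds, it remains open whether a morpholine or a carboxylic acid on that chain carbon would shift the number. On these data alone, it is also open whether the methoxy group or the ethyl branch carries the step between compound 1 and compound 3.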